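From a Lactam to an Amino Ester on the Shared Core

The source may hold more compounds than are shown below. What is called first, only, known or untested is meant among the compounds shown, and "the series" means these compounds.

In an assay on VSM-A10 cells for antagonist activity at Endothelin-1 receptor (Rattus norvegicus) (a higher number here means a weaker inhibitor, a lower number a stronger inhibitor), compound 2 `Cc1noc(NS(=O)(=O)c2cccc3c(N4CCCCC4=O)cccc23)c1C` gives 270 nM, the lowest of the two numbers in hand. Compound 1 `CCCNc1ccc(S(=O)(=O)Nc2onc(C)c2C)cc1` gives 27000 nM in this assay, a gap well beyond the scatter. Compound 3 `Nc1ccc(S(=O)(=O)Nc2noc3c2CCCC3)cc1` sits at the limit of > 32000 nM in this assay, at which 1 of the 3 values shown sits, giving > 32000 nM, which is a limit of this assay rather than a number. Among the compounds with values here, no step between two measured compounds that differ in a single place is available. Compound 4 `CCOC(=O)C(C)Nc1cccc2c(S(=O)(=O)Nc3onc(C)c3C)cccc12` differs from compound 2 by (1-(ethoxycarbonyl)ethyl)amino in place of 2-oxopiperidin-1-yl on an aromatic carbon. Within the data shown here, with no measured step on the shared core to lean on, the step is expected to be modest and toward a weaker inhibitor: a 3.7-fold higher number from compound 2 to compound 4 (0.57 log units; beyond the scatter). Compound 4 is therefore estimated at 1000 nM, within a range from 200 nM to 6000 nM.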

Compound 4, half-maximal inhibitory concentration: 400 nM
Compound 4: middle estimate off by 2.5-fold (0.40 log units), on the high side; the measured number falls inside the stated range.
By their numbers in this assay, from the lowest: compounds 2 and 4 (each within the scatter of the next); then compound 1. At a limit, above all of these: compound 3.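

In this assay, the group on this aromatic carbon of the shared core need not be a ring: with (1-(ethoxycarbonyl)ethyl)amino in place of 2-oxopiperidin-1-yl, the change is a 1.5-fold higher number from compound 2 to compound 4 (0.17 log units; within the scatter). Within the data shown here, this is the first step read on this core, and it places an open chain bearing an ethyl ester level with the lactam. Nothing measured here gives a reason for this outcome. Still open, as far as these compounds go, is whether the ester matters, and how a carboxylic acid or a primary amide would read at this position.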